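Swapping Chloro for Acetyl at One Aromatic Carbon

The source may report more compounds than this note shows. Statements on the series, on what has been measured and on what is new or still open speak of the compounds shown alone.

Within the data shown here, compound 1 `COc1cc(-c2ccnc3cc(-c4ccc(Cl)cc4)nn23)cc(OC)c1OC` is one of two compounds so far measured in a functional assay on A549 cells (Homo sapiens) for inhibition, read by CCK-8 assay, with a stated time of 48 h (on this read-out higher numbers stand for weaker inhibition and lower numbers for stronger inhibition), where compound 1 gives 3070 nM. Compound 2 `C=Cc1ccc(-c2cc3nccc(-c4cc(OC)c(OC)c(OC)c4)n3n2)cc1` differs from it in a single place, and in this assay compound 2 gives 1030 nM. That single change, vinyl in place of chloro on an aromatic carbon, produced a 3.0-fold lower number from compound 1 to compound 2 (0.47 log units; beyond the scatter). Of the two numbers recorded, compound 1 therefore stands at the higher end, the weaker inhibitor of the pair.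

Compound 3 `COc1cc(-c2ccnc3cc(-c4ccc(C(C)=O)cc4)nn23)cc(OC)c1OC` has not yet been measured in this assay. Among the measured compounds shown here, it too starts from compound 1 and alters the same place: acetyl in place of chloro on an aromatic carbon The only measured step that bears on this is the one from compound 1 to compound 2, which was modest yet beyond the scatter. Since acetyl is not vinyl, that step is only a loose guide, and a change of similar or smaller size is expected, more likely toward a lower number than a higher one. For compound 3 the expected result is 2000 nM, within a range of 700 nM to 6000 nM. This estimate amounts to an expected 1.5-fold lower number from compound 1 to compound 3 (0.19 log units; within the scatter).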

Compound 3, half-maximal inhibitory concentration: 4100 nM
Compound 3: the middle estimate sits 2.1-fold (0.31 log units) below what was measured, and the stated range covers the measured number.
By their numbers in this assay, from the lowest: compound 2; then compounds 1 and 3 (each within the scatter of the next).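

At this place on the ring, para to a large group, acetyl and chloro cannot be told apart in this assay: the result is a 1.3-fold higher number from compound 1 to compound 3 (0.13 log units; within the scatter), even though acetyl brings a carbonyl and a hydrogen-bond acceptor that chloro lacks. The position still responds to what sits there, as replacing vinyl with acetyl gives a 4.0-fold higher number from compound 2 to compound 3 (0.60 log units; beyond the scatter), so the earlier gain seen with vinyl does not extend to acetyl, and compound 2 alone stands apart from the other two compounds. Nothing available explains why vinyl differs from acetyl here, and no measurement beyond these numbers bears on the question.

As far as these compounds go, how an amine, a carboxylic acid or a longer carbon chain would read at this place remains open, as does whether ethyl, the saturated relative of vinyl, would match compound 2. Among these compounds, with only three groups compared on one core, the results mark out no general rule for this position, and the vinyl result may prove a special case or the first sign of a wider trend.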